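Clearance in the quinoline acid series: carboxy to methylsulfonyl

The source may hold more compounds than are shown below. What is called first, only, known or untested is meant among the compounds shown, and "the series" means these compounds.

Compound 3 `CCC(CSC(CCc1ccccc1C(=O)O)c1cccc(OCc2ccc3ccc(Cl)cc3n2)c1)C(=O)O` gives 8.8 mL/min/kg in an in vivo ADME assay on the whole organism (plasma) for pharmacokinetics, with Rattus norvegicus as the target, at a dose of 5 mg/kg by the intravenous route (a higher number here means faster removal of the compound, a lower number slower removal), the lowest of the three values recorded. Compound 1 `CCC(CSC(CCc1ccccc1C#N)c1cccc(CCc2ccc3ccc(Cl)cc3n2)c1)C(=O)O` gives 13 mL/min/kg, a gap within the scatter, so the two cannot be ordered. Compound 2 `CS(=O)(=O)Nc1ccccc1CCC(SCCC(=O)O)c1cccc(OCc2ccc3ccc(Cl)cc3n2)c1` gives 131 mL/min/kg, a gap beyond the scatter.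

Compound 4 `CCC(CSC(CCc1ccccc1S(C)(=O)=O)c1cccc(OCc2ccc3ccc(Cl)cc3n2)c1)C(=O)O` differs from compound 3 in one place: methylsulfonyl in place of carboxy on an aromatic carbon. Within the data shown here, no measured pair shows this change directly. Among the measured compounds shown here, compound 2, the only compound here carrying a single carboxy, gives 131 mL/min/kg in this assay, and on that basis a rise in clearance beyond the scatter is expected for compound 4, the estimated step being a 4.5-fold higher number from compound 3 to compound 4 (0.66 log units; beyond the scatter). Compound 4 is therefore expected to give about 40 mL/min/kg, with a range of 12 mL/min/kg to 130 mL/min/kg.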

Compound 4, clearance: 35 mL/min/kg
For compound 4 the middle estimate is 1.1-fold (0.06 log units) above the measured one, and the stated range covers the measured number.
By their numbers in this assay, from the lowest: compounds 3 and 1 (each within the scatter of the next); then compound 4; then compound 2.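

In this assay, among these compounds, methylsulfonyl in place of carboxy on an aromatic carbon, ortho to a large group, gives a 4.0-fold higher number from compound 3 to compound 4 (0.60 log units; beyond the scatter) and is the first direct reading of a change at this position. Among the compounds shown here, with the rest of the structure held constant, this step belongs to the single substituent swap. No available measurement accounts for the rise.

One pair cannot separate the loss of carboxy from the entry of methylsulfonyl. A primary carboxamide or a methyl ester at this position would test how clearance responds to other replacements.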